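The compounds below may be only part of what the source reports. "The series", "measured", "known", "first", "only" and "open" are said of these compounds alone.

Among the measured compounds shown here, in a functional assay on B16 cells (Mus musculus) for cytotoxicity, read by MTT assay (a lower number here means a stronger inhibitor, a higher number a weaker inhibitor), compound 2 `CC(=O)O[C@@H]1OC(=O)[C@@](Cc2ccccc2)(C(C)=O)[C@@H]1C` gives 45000 nM, the highest of the two numbers measured so far, while compound 1 `CC(=O)O[C@@H]1OC(=O)[C@@](C)(C(C)=O)[C@@H]1C` gives 14000 nM. For the measured compounds named here, the only measured step, a 3.2-fold higher number from compound 1 to compound 2 (0.51 log units; beyond the scatter), concerns a change at the same ring carbon, though not the group that now enters. Compound 3 `CC(=O)O[C@@H]1OC(=O)[C@@](OC(C)=O)(C(C)=O)[C@@H]1C` differs from compound 2 by acetoxy in place of benzyl on a saturated ring carbon. Going by the values given here, no measured step involves acetoxy at this place, so the direction rests on removing the benzyl alone. Because a 3.2-fold higher number from compound 1 to compound 2 (0.51 log units; beyond the scatter) was modest, the expected step is a 2.3-fold lower number from compound 2 to compound 3 (0.35 log units; beyond the scatter), toward a lower number. Compound 3 is expected to give 20000 nM, within 7000 nM to 60000 nM.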

Compound 3, half-maximal inhibitory concentration: > 50000 nM
Compound 3: a limit, no number; the forecaster's own chance of this, stated with the estimate: 10%; middle value at least 2.5-fold (0.39 log units) away from the limit.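

Compound 3 gives a limit, not a number, in this assay: the limit of > 50000 nM in this assay, at which 1 of the 3 values shown sits.

This limit gives an at least 1.1-fold higher number from compound 2 to compound 3 (0.04 log units; that floor lies within the scatter), so benzyl and acetoxy cannot be put in order at this ring carbon. By contrast, the result gives an at least 3.5-fold higher number from compound 1 to compound 3 (0.55 log units; beyond the scatter), so acetoxy, like benzyl, gives a higher number than methyl here, meaning a weaker inhibitor.

Still open, going by these compounds, is whether a hydroxyl, an amine or a longer alkyl chain on this ring carbon would give a lower number than methyl does.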